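A Methyl for Chloro Swap on the Outer Ring

The source may report more compounds than this note shows. Statements on the series, on what has been measured and on what is new or still open speak of the compounds shown alone.

Four compounds share one core and differ only in the outer ring. Compound 1 `Oc1ccccc1CNc1ccc(-c2ccc(Cl)cc2)cc1` gives 2390 nM in a functional assay on Jurkat cells (Homo sapiens) for activation, with a stated time of 24 h; on this read-out lower numbers stand for an effect already at smaller amounts and higher numbers for an effect only at larger amounts of compound. Compound 2 `Cc1ccc(-c2ccc(NCc3ccccc3O)cc2)cc1` gives 3790 nM, a step of a 1.6-fold higher number from compound 1 to compound 2 (0.20 log units; within the scatter) through (methyl in place of chloro on an aromatic carbon). Compound 3 `Oc1ccccc1CNc1ccc(-c2cccc(Cl)c2)cc1` gives 6200 nM, a step of a 2.6-fold higher number from compound 1 to compound 3 (0.41 log units; beyond the scatter) through (3-chlorophenyl in place of 4-chlorophenyl on an aromatic carbon); from compound 2 the step is a 1.6-fold higher number from compound 2 to compound 3 (0.21 log units; within the scatter). Compound 4 `Cc1cccc(-c2ccc(NCc3ccccc3O)cc2)c1` is not yet measured; it arises from compound 3 through (methyl in place of chloro on an aromatic carbon). This is the same kind of change as from compound 1 to compound 2, yet the place differs: there the group sits para to a large group, here meta to a large group. Because a 1.6-fold higher number from compound 1 to compound 2 (0.20 log units; within the scatter) was small, the expected step of a 1.4-fold higher number from compound 3 to compound 4 (0.14 log units; within the scatter) is similar, giving an estimate for compound 4 of 8500 nM, between 4000 nM and 18000 nM.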

Compound 4, half-maximal effective concentration: 9190 nM
Compound 4: middle estimate off by 1.1-fold (0.03 log units), on the low side; measured number inside the range.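

Methyl in place of chloro gives a 1.5-fold higher number from compound 3 to compound 4 (0.17 log units; within the scatter), and in this assay this change reads the same on both cores: the same change on two cores in this assay, a 1.6-fold higher number (0.20 log units; within the scatter) from compound 1 to compound 2 and a 1.5-fold higher number (0.17 log units; within the scatter) from compound 3 to compound 4, 1.1-fold (0.03 log units) apart, within the scatter of two such steps

The steps beyond the scatter are those that also move the group on the outer ring, a 2.4-fold higher number from compound 2 to compound 4 (0.38 log units; beyond the scatter) and a 3.8-fold higher number from compound 1 to compound 4 (0.58 log units; beyond the scatter), the second combining the move with the methyl for chloro swap. Within the data shown here, the agreement rests on only two pairs, each with a step within the scatter, and it does not show that the swap would behave alike on any other core.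

Going by these compounds, whether a different group in place of chloro, such as an amine or a carboxylic acid, would carry across these two cores in the same way stays open.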